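The compounds below may be only part of what the source reports. "The series", "measured", "known", "first", "only" and "open" are said of these compounds alone.

Of the compounds shown here, two of one shared core have been tested in an assay on isolated protein for binding affinity to Alpha-1D adrenergic receptor (Rattus norvegicus), read by radioligand binding; on this read-out lower numbers stand for stronger inhibition and higher numbers for weaker inhibition. Compound 1 `CCS(=O)(=O)Nc1cccc2c1CCCC2c1c[nH]cn1` carries an ethylsulfonyl group on the ring nitrogen; in this assay compound 1 gives 1070 nM. Compound 2 `COC(=O)Nc1cccc2c1CCCC2c1c[nH]cn1` carries a methoxycarbonyl group at the same place, and in this assay compound 2 gives 3020 nM. Among the measured compounds shown here, compound 2 thus stands at the higher of the two numbers: the single measured step, a 2.8-fold higher number from compound 1 to compound 2 (0.45 log units; beyond the scatter), shows that swapping the ethylsulfonyl for the methoxycarbonyl weakened binding by a modest but real amount.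

Compound 3 `CC(C)S(=O)(=O)Nc1cccc2c1CCCC2c1c[nH]cn1` is not yet measured. It differs from compound 2 in one place: isopropylsulfonyl in place of methoxycarbonyl on a nitrogen on an aromatic ring. This is close to the measured step run backwards, a sulfonyl group again replacing the methoxycarbonyl, so a lower number of roughly the size of a 2.8-fold higher number from compound 1 to compound 2 (0.45 log units; beyond the scatter) is the natural expectation; how the isopropyl chain compares with the ethyl chain is not known from any measured pair. For compound 3 the expected step is therefore a 3.0-fold lower number from compound 2 to compound 3 (0.48 log units; beyond the scatter), and the estimate is 1000 nM, with a range from 400 nM to 2500 nM.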

Compound 3, inhibition constant: 2040 nM
Compound 3: the middle estimate sits 2.0-fold (0.31 log units) below what was measured, and the stated range covers the measured number.
By their numbers in this assay, from the lowest: compounds 1, 3 and 2 (each within the scatter of the next, the first and the last beyond it).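

In this assay the clear gap seen earlier does not return with the new sulfonyl compound: the step reads a 1.5-fold lower number from compound 2 to compound 3 (0.17 log units; within the scatter), so at this nitrogen on an aromatic ring, putting a sulfonyl group in place of methoxycarbonyl does not by itself give a difference that can be told from scatter. The added methyl on the saturated chain carbon, read as a 1.9-fold higher number from compound 1 to compound 3 (0.28 log units; within the scatter), is also too small to separate the isopropylsulfonyl compound from its ethylsulfonyl partner, so compound 3 cannot be told apart from either neighbour even though compound 1 and compound 2 stand clearly apart, and that earlier gap holds for that one pair and not for sulfonyl groups as a class. Nothing at hand offers an explanation for this picture.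

Still open, as far as these compounds go, is whether a longer chain on the sulfur, such as butyl, or a ring there, such as phenyl, would move the number clearly in either direction. Equally open, from the compounds shown here alone, is how the bare amine, with neither a sulfonyl nor a carbonyl group on the nitrogen, or a simple acetyl group would compare with these three compounds.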